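The source may hold more compounds than are shown below. What is called first, only, known or untested is meant among the compounds shown, and "the series" means these compounds.

Of the compounds shown here, two have been measured in a functional assay on ACHN cells (Homo sapiens) for cytotoxicity, read by sulforhodamine B assay, with a stated time of 48 h, tested at 10 uM; on this read-out lower numbers stand for a stronger effect and higher numbers for a weaker effect at the one concentration tested. Compound 1 `COc1ccc(-c2cc(/C=C/C(=O)c3ccc(OC)c(OC)c3)[nH]n2)cc1` gives -58% there. Compound 2 `COc1cc(-c2cc(/C=C/C(=O)c3ccc(Cl)c(Cl)c3)[nH]n2)cc(OC)c1OC` gives 67%, the higher of the two numbers, and its gap to compound 1 lies well beyond the usual scatter, so the two values show compound 2 as the weaker of the pair on this read-out. Compound 3 `COc1ccc(C(=O)/C=C/c2cc(-c3cc(OC)c(OC)c(OC)c3)n[nH]2)cc1OC` has not yet been measured. It differs from compound 2 in one place: 3,4-dimethoxyphenyl in place of 3,4-dichlorophenyl on a carbonyl carbon. Among the measured compounds shown here, no measured pair in this set shares that single change, so the size of its effect cannot be taken from a recorded step. Compound 1 does carry the 3,4-dimethoxyphenyl on its carbonyl carbon and gives the lower number, but it also differs from compound 3 elsewhere, so it offers only a loose pointer. Compound 3 is therefore expected to land between the two measured numbers, with wide uncertainty. The expected step of a number 57 percentage points lower from compound 2 to compound 3 (beyond the scatter) is a move toward a stronger effect. The estimate for compound 3 is 10%, ranging from -55% to 65%.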

Compound 3, a percentage reported as activity, at one concentration (the size of the read-out at that concentration, not a potency): -95%
The estimate for compound 3 lay 105 percentage points above the measured number; measured number outside the range, below it.
By their numbers in this assay, from the lowest: compound 3; then compound 1; then compound 2.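

Among the compounds shown here, with the rest of the structure held constant, the first recorded step at this position shows that replacing 3,4-dichlorophenyl with 3,4-dimethoxyphenyl on the carbonyl carbon has a large effect in this assay, with a move a number 162 percentage points lower from compound 2 to compound 3 (beyond the scatter) toward a stronger effect. The change also takes the read-out across zero: compound 2 gives 67%, whereas compound 3 gives -95%, so the group on the carbonyl carbon strongly shapes the outcome on this core.

This single pair cannot separate the arrival of the two methoxy groups from the loss of the two chlorines, and it does not show whether the step would have the same size on another core. It also leaves open how a ring with a single methoxy group, a hydroxyl group, an amine or a carboxylic acid at this place would read out in this assay. No measured evidence is available to explain the size of this step.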